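A few compounds are considered here, and "the series" means these few. Any claim that something is new, unique, unknown or untested is made for them only; others in the source may bear on it.

Measured so far in a functional assay on MCF7 cells (Homo sapiens) for antiproliferative activity, read by sulforhodamine B assay, with a stated time of 48 h; a lower number here means a stronger inhibitor, a higher number a weaker inhibitor:
- Compound 1 `O=C1NCCN1c1ccc(S(=O)(=O)Nc2ccc(C3CCCCC3)cc2)cc1` gives > 1000 nM (a limit of the assay, not a number)
- Compound 2 `O=C1NCCN1c1ccc(S(=O)(=O)Nc2ccc(F)cc2)cc1` gives 690 nM
- Compound 3 `O=C1NCCN1c1ccc(S(=O)(=O)Nc2ccc(I)cc2)cc1` gives 600 nM

Compound 3 has a measured value, and so does compound 2, but the two cannot be told apart: the gap is a 1.2-fold lower number from compound 2 to compound 3 (0.06 log units; within the scatter). Swapping one halogen for the other at this place therefore shows no clear effect.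

Compound 4 `CCCCCCCc1ccc(NS(=O)(=O)c2ccc(N3CCNC3=O)cc2)cc1` differs from compound 3 by heptyl in place of iodo on an aromatic carbon. Going by the values given here, no measured compound carries heptyl. The nearest guide is compound 1, which has cyclohexyl at the same place and, like heptyl, is built of carbon alone, although heptyl has no ring.

Among the compounds with values here, two measured steps bear on the change: an at least 1.4-fold lower number from compound 1 to compound 2 (0.16 log units; that floor lies within the scatter) and an at least 1.6-fold lower number from compound 1 to compound 3 (0.22 log units; that floor lies within the scatter). Both are only floors, so the guidance is weak. Read in reverse, they point to a higher number in this assay on going from iodo to heptyl.

The expected step is a 2.2-fold higher number from compound 3 to compound 4 (0.34 log units; beyond the scatter). The estimated value for compound 4 is 1300 nM, with an expected range from 500 nM to 4000 nM. The assay may well report only a limit for it, as happened with the cyclohexyl compound.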

Compound 4, half-maximal inhibitory concentration: > 1000 nM
Compound 4: a limit, no number; the forecaster's own chance of this, stated with the estimate: 55%; the middle value lies beyond the limit too.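

In this assay compound 4 gives > 1000 nM, which is a limit of the assay and not a number. Set against the two halogen compounds, the change reads as an at least 1.6-fold higher number from compound 3 to compound 4 (0.22 log units; that floor lies within the scatter) and an at least 1.4-fold higher number from compound 2 to compound 4 (0.16 log units; that floor lies within the scatter); both are only floors and both lie within the scatter, so neither step alone proves a real loss of activity on moving to heptyl. What is new is that heptyl, built of carbon alone and with no ring, ends at the same limit as cyclohexyl, which has a ring, whereas fluoro and iodo at this place both return actual numbers, so a ring in the group is not needed to reach that limit: the limit of > 1000 nM in this assay, at which 2 of the 4 values shown sit.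

Going by these compounds, the step between compound 1 and compound 4 cannot be read, so how far each lies past the limit, and whether the two differ at all, stays unknown. Also open, on these data alone, is what a shorter chain such as propyl, an amine or a carboxylic acid would give on this aromatic carbon, and whether any such group would return a number lower than those of the halogen compounds.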